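The compounds below may be only part of what the source reports. "The series", "measured", "known", "first", "only" and "open" are said of these compounds alone.

Compound 1 `CC#CCn1c(N2CCC[C@@H](N)C2)nc2c1c(=O)n(CCCN1CCN(c3ncc(F)cn3)CC1)c(=O)n2C` and compound 2 `CC#CCn1c(N2CCC[C@@H](N)C2)nc2c1c(=O)n(CCCN1CCN(c3ncc(CCC)cn3)CC1)c(=O)n2C` share one core and differ only in the group on the aromatic ring that hangs from the ring nitrogen of the six-membered ring with two nitrogens. In a functional assay on HEK293 cells for agonist activity at Glucose-dependent insulinotropic receptor (Homo sapiens), read by a luciferase reporter (on this read-out higher numbers stand for an effect only at larger amounts of compound and lower numbers for an effect already at smaller amounts), compound 1 gives 1410 nM, and in the same assay compound 2 gives 1850 nM. Among the compounds with values here, the one step measured so far, a 1.3-fold higher number from compound 1 to compound 2 (0.12 log units; within the scatter), changes nothing beyond the scatter, so the two numbers cannot be ranked; compound 2 simply sits at the higher of the two with compound 1 close by.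

Compound 3 `CC#CCn1c(N2CCC[C@@H](N)C2)nc2c1c(=O)n(CCCN1CCN(c3nc(-c4ccccc4)ns3)CC1)c(=O)n2C` takes the change (3-phenyl-1,2,4-thiadiazol-5-yl in place of 5-propylpyrimidin-2-yl on an amine nitrogen in a ring). Within the data shown here, this is a larger change than the measured step: a whole ring with its attached phenyl replaces the former ring, and it is the only measured step that bears on it at all, and it was within the scatter. With nothing showing that this part of the molecule moves the read-out, the number for compound 3 is expected to stay near that of compound 2, with a step of about a 1.2-fold lower number from compound 2 to compound 3 (0.06 log units; within the scatter). The estimate for compound 3 in this assay is 1600 nM, within a range from 400 nM to 6500 nM.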

Compound 3, half-maximal effective concentration: 1930 nM
For compound 3 the middle estimate is 1.2-fold (0.08 log units) below the measured one; the range from low to high includes it.
By their numbers in this assay, from the lowest: compounds 1, 2 and 3 (each within the scatter of the next).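

In this assay, the step of a 1.0-fold higher number from compound 2 to compound 3 (0.02 log units; within the scatter) and the step of a 1.4-fold higher number from compound 1 to compound 3 (0.14 log units; within the scatter) both leave the number unchanged beyond the usual scatter, so compounds 1, 2 and 3 cannot be ranked. The earlier pair differed only in the small group carried by the same pyrimidine ring, whereas here the whole group on the amine nitrogen is exchanged: a five-membered aromatic ring with 3 hetero atoms, carrying a six-membered aromatic ring of carbon only, replaces the six-membered aromatic ring with 2 hetero atoms. Among these three compounds, even this larger exchange does not separate the read-outs, and no measurement shown explains why.

On these data alone, all three compounds carry an aromatic ring on this amine nitrogen, so what a carboxylic acid, a primary amine or a plain alkyl chain would do there remains open. As far as these compounds go, it also remains open whether any group at this place can shift the number beyond the scatter, or whether changes elsewhere on the shared core matter more.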